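From Oxetan-3-yl to a Larger Ring in Compound 4

A few compounds are considered here, and "the series" means these few. Any claim that something is new, unique, unknown or untested is made for them only; others in the source may bear on it.

In a functional assay on HT-29 cells (Homo sapiens) for inhibition, read by luminescence and CellTiter-Glo, with a stated time of 24 h (a higher number here means that more compound is needed for the effect, a lower number that less compound is needed), compound 3 (`CN1C(=S)[C@@H](NC(=O)c2nc(Cc3ccccc3)n(C3COC3)n2)COc2ccccc21`) reads 916 nM and sits within the scatter of compound 1 (`CC(C)Cn1nc(C(=O)N[C@H]2COc3ccccc3N(C)C2=S)nc1Cc1ccccc1`), which reads 1230 nM and shares the low end of the series. Compound 2 (`CN1C(=S)[C@@H](NC(=O)c2nc(Cc3ccccc3)n(CCCF)n2)COc2ccccc21`) stands clearly apart at 4760 nM in the same test. Compound 4 (`CN1C(=S)[C@@H](NC(=O)c2nc(Cc3ccccc3)n(C3CCN(C(=O)OC(C)(C)C)C3)n2)COc2ccccc21`) differs from compound 3 in one place (a group of 12 heavy atoms (9 carbon, 1 nitrogen, 2 oxygen; one five-membered non-aromatic ring with 1 hetero atom) in place of a group of 4 heavy atoms (3 carbon, 1 oxygen; one four-membered non-aromatic ring with 1 hetero atom), on an aromatic nitrogen).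

The measured changes on that nitrogen are the closest guide. Oxetan-3-yl in place of isobutyl gave a 1.3-fold lower number from compound 1 to compound 3 (0.13 log units; within the scatter) and oxetan-3-yl in place of 3-fluoropropyl gave a 5.2-fold lower number from compound 2 to compound 3 (0.72 log units; beyond the scatter) in the same direction. The related change between the two chains gave a 3.9-fold higher number from compound 1 to compound 2 (0.59 log units; beyond the scatter) as a further measure of what this position can do. No group as large as the entering one has been measured, so the guide is weak. A modest rise is expected, since compound 3 already lies at the low end. The expected change is a 2.0-fold higher number from compound 3 to compound 4 (0.29 log units; within the scatter) in this assay. Compound 4 is estimated at 1800 nM (between 500 nM and 6500 nM).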

Compound 4, half-maximal effective concentration: > 10000 nM
Compound 4 gave a limit, no number; the forecaster's own chance of this, stated with the estimate: 5%; middle value at least 5.5-fold (0.74 log units) away from the limit.
By their numbers in this assay, from the lowest: compounds 3 and 1 (each within the scatter of the next); then compound 2. At a limit, above all of these: compound 4.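

In this assay, among the compounds shown here, the larger ring-bearing group on the aromatic nitrogen gave an at least 10-fold higher number from compound 3 to compound 4 (1.03 log units; beyond the scatter), a step that is larger than any seen among the earlier compounds at this position. For the compounds shown here, the same group gave an at least 8.1-fold higher number from compound 1 to compound 4 (0.91 log units; beyond the scatter) and an at least 2.1-fold higher number from compound 2 to compound 4 (0.32 log units; beyond the scatter), so the change separates compound 4 even from compound 2, which had the highest number of the earlier compounds. The reading of compound 4 is a limit of the assay and not a number: the limit of > 10000 nM in this assay, at which 1 of the 4 values shown sits.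

The compounds shown leave open which part of the entering group goes with this loss, the five-membered ring itself or what is carried on its nitrogen. A free amine on that ring, or a longer chain ending in an ether oxygen, would be needed to separate the two.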